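A few compounds are considered here, and "the series" means these few. Any claim that something is new, unique, unknown or untested is made for them only; others in the source may bear on it.

Compound 1 `CCN(c1ccnc(Nc2ccc(C#N)cc2)n1)c1c(F)cc(-c2ccc(C#N)cc2)cc1F` gives 105000 nM in an ADME assay on MT4 cells (Homo sapiens) for cytotoxicity, read by MTT assay, with a stated time of 5 days (on this read-out lower numbers stand for higher toxicity in this test and higher numbers for lower toxicity in this test), the lowest of the three numbers measured. Compound 2 `CC(C)N(c1ccnc(Nc2ccc(C#N)cc2)n1)c1c(F)cc(-c2ccc(C#N)cc2)cc1F` gives 172000 nM, reached by a 1.6-fold higher number from compound 1 to compound 2 (0.21 log units; within the scatter). Compound 3 `N#Cc1ccc(Nc2nccc(N(CCCF)c3c(F)cc(-c4ccc(C#N)cc4)cc3F)n2)cc1` gives 241000 nM, reached by a 2.3-fold higher number from compound 1 to compound 3 (0.36 log units; beyond the scatter); between compound 2 and compound 3 the step is a 1.4-fold higher number from compound 2 to compound 3 (0.15 log units; within the scatter). Compound 4 `N#Cc1ccc(Nc2nccc(N(CCCCl)c3c(F)cc(-c4ccc(C#N)cc4)cc3F)n2)cc1` differs from compound 1 by chloromethyl in place of hydrogen on a saturated chain carbon, two bonds along the chain from a nitrogen on an aromatic ring. The closest guide is the step from compound 1 to compound 3, which changes the same place with fluoromethyl and was modest but beyond the scatter. A step of similar size and direction is therefore expected for compound 4, estimated as a 1.9-fold higher number from compound 1 to compound 4 (0.28 log units; within the scatter) in this assay. Compound 4 is thus expected to give 200000 nM, within a range from 100000 nM to 400000 nM.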

Compound 4, half-maximal cytotoxic concentration: > 250000 nM
Compound 4 ended at the assay's limit (the forecaster's own chance of this, stated with the estimate: 20%); middle value at least 1.2-fold (0.09 log units) away from the limit.
By their numbers in this assay, from the lowest: compounds 1, 2 and 3 (each within the scatter of the next, the first and the last beyond it). At a limit, above all of these: compound 4.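

In this assay, chloromethyl at this place gives an at least 2.3-fold higher number from compound 1 to compound 4 (0.37 log units; beyond the scatter), so a second halogen-bearing chain moves the same way as the fluoromethyl one. Against the other chains, the change gives an at least 1.0-fold higher number from compound 3 to compound 4 (0.01 log units; that floor lies within the scatter) and an at least 1.4-fold higher number from compound 2 to compound 4 (0.16 log units; that floor lies within the scatter), and these floors settle no order among the three. Compound 4 stands at a limit, not at a number: the limit of > 250000 nM in this assay, at which 1 of the 4 values shown sits.

The compounds shown leave open whether a longer chain, an amine or a carboxylic acid at this place would keep the number as high, and whether bromo would match chloro.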